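Chloro between ring nitrogens of a purine-like core

This account rests on a few compounds, and the source may have more. Where it says the series, first, only, none or still open, it means among the compounds named here.

Measured compounds:
compound 1, `ClCc1ccc(Cn2cnc3c(Cl)ncnc32)cc1` — a functional assay on SW-620 cells (Homo sapiens) for cytotoxicity, read by sulforhodamine B assay, with a stated time of 48 h; a higher number here means that more compound is tolerated, a lower number that less compound is tolerated: "not determined" (no result reported)
compound 2, `ClCc1cccc(Cn2cnc3c(Cl)ncnc32)c1` — this assay: 8910 nM

Compound 1 has no single number in this assay; it is recorded only as "not determined" (no result reported). For the measured compounds named here, compound 2, the isomer, gives 8910 nM in this assay, which is the only value available. Compound 3, `ClCc1ccc(Cn2cnc3c(Cl)nc(Cl)nc32)cc1`, differs from compound 1 by chloro in place of hydrogen on an aromatic carbon. Going by the values given here, with no measured pair sharing this change, no direction can be derived; a modest step in this assay, not beyond the scatter, is the default expectation. The reading for compound 3 in this assay is estimated at 6000 nM, with a range from 1500 nM to 25000 nM.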

Compound 3, concentration lethal to 50% of the cells: 56200 nM
Compound 3: middle estimate off by 9.4-fold (0.97 log units), on the low side; measured number outside the range, above it.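

In this assay, for the compounds shown here, compound 1 carries no single number, so no step to compound 3 can be read. Nothing shown bears on the reading of compound 3.

From the compounds shown here alone, what the chloro between two ring nitrogen atoms does in this assay remains open.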